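A few compounds are considered here, and "the series" means these few. Any claim that something is new, unique, unknown or untested is made for them only; others in the source may bear on it.

Measured compounds:
- Compound 1, `Cc1cccc(-n2nncc2CN2C(=O)C3(C(C#N)=C(N)Oc4c3c3nc5ccccc5nc3c3ccccc43)c3ccccc32)c1`, gives 39600 nM in a functional assay on A549 cells (Homo sapiens) for antiproliferative activity, read by MTT assay, with a stated time of 48 h; on this read-out lower numbers stand for stronger inhibition and higher numbers for weaker inhibition.
- Compound 2, `CC(=O)Nc1ccc(-n2nncc2CN2C(=O)C3(C(C#N)=C(N)Oc4c3c3nc5ccccc5nc3c3ccccc43)c3ccccc32)cc1`, gives > 50000 nM, which is a limit of the assay and not a number.
- Compound 3, `N#CC1=C(N)Oc2c(c3nc4ccccc4nc3c3ccccc23)C12C(=O)N(Cc1cnnn1-c1ccc(S(N)(=O)=O)cc1)c1ccccc12`, gives > 50000 nM, again a limit of the assay and not a number.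

For the measured compounds named here, compound 1 thus stands as the only compound with a number in this assay; the two other results are the limit of > 50000 nM in this assay, at which 2 of the 3 values shown sit. Compound 4, `Cc1cc(C)cc(-n2nncc2CN2C(=O)C3(C(C#N)=C(N)Oc4c3c3nc5ccccc5nc3c3ccccc43)c3ccccc32)c1`, is the compound not yet measured. It differs from compound 1 by methyl in place of hydrogen on an aromatic carbon, so that the 3-methylphenyl becomes a 3,5-dimethylphenyl.

Going by the values given here, no measured step makes this same change. The two steps that start from compound 1 exchange the whole 3-methylphenyl for another ring: an at least 1.2-fold higher number from compound 1 to compound 2 (0.10 log units; that floor lies within the scatter), and an at least 1.2-fold higher number from compound 1 to compound 3 (0.10 log units; that floor lies within the scatter). Between the two limits, a step that the two limits leave unreadable from compound 2 to compound 3. Each of these brings in a polar group where compound 4 only gains a methyl, so they guide the expectation only loosely.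

With compound 1 already weak in this assay and no step shown for a methyl in place of hydrogen, the expected change is a 1.1-fold lower number from compound 1 to compound 4 (0.04 log units; within the scatter), none beyond the scatter. Compound 4 is therefore estimated at 36000 nM, with a range from 15000 nM to 80000 nM.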

Compound 4, half-maximal inhibitory concentration: > 50000 nM
Compound 4 was reported as a limit; the forecaster's own chance of this, stated with the estimate: 35%; at least 1.3-fold (0.14 log units) between middle value and limit.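

Compound 4 is reported only as a limit of the assay and not as a number. Its step is the first shown that keeps the aromatic ring of compound 1 and only adds a methyl, and in this assay this addition brings no lower number (an at least 1.2-fold higher number from compound 1 to compound 4 (0.10 log units; that floor lies within the scatter)), so a second methyl on this ring gives no sign of stronger inhibition, while any weakening stays unproven. For the compounds shown here, the steps from compound 2 and compound 3 to compound 4 join two limits and cannot be read, which leaves compound 1 as the only compound with a true number and the series with little room to show differences: the limit of > 50000 nM in this assay, at which 3 of the 4 values shown sit.

The compounds shown leave open whether any group on this ring can bring the number clearly down, for example a chlorine, a methoxy, an amine or a carboxylic acid in place of the methyl groups. They also leave open how a plain phenyl would read, or a longer chain in place of the aromatic ring, since every ring shown here carries a substituent.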